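Fluorinated ether chain extension on the shared core

This account rests on a few compounds, and the source may have more. Where it says the series, first, only, none or still open, it means among the compounds named here.

Compound 1 `Cc1cc(Nc2nc3nonc3nc2O)ccc1OCC(F)(F)F`: 7000 nM in an assay on mitochondria from L6 cells (Rattus norvegicus) for activation, with a stated time of 90 min; a lower number here means that less compound is needed, a higher number that more compound is needed for the effect
Compound 2 `Oc1nc2nonc2nc1Nc1ccc(OCC(F)(F)F)c(C(F)(F)F)c1`: 4000 nM in this assay

Compound 2 stands lowest of the two numbers, and the gap to the nearest compound is only a 1.8-fold lower number from compound 1 to compound 2 (0.24 log units; within the scatter). Compound 3 `Oc1nc2nonc2nc1Nc1ccc(OCCCC(F)(F)F)c(C(F)(F)F)c1` differs from compound 2 by 3,3,3-trifluoropropyl in place of trifluoromethyl on a saturated chain carbon bound to an oxygen on an aromatic ring. Among the measured compounds shown here, no measured step touches this chain; the one step known, a 1.8-fold lower number from compound 1 to compound 2 (0.24 log units; within the scatter), concerns the group on the aromatic carbon and lies within the scatter. The expected change is therefore no change at the digits printed from compound 2 to compound 3 (within the scatter), nothing beyond the scatter. Compound 3 is estimated at 4000 nM, within 1500 nM to 12000 nM.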

Compound 3, half-maximal effective concentration: 2100 nM
For compound 3 the middle estimate is 1.9-fold (0.28 log units) above the measured one, within the range that was stated.
By their numbers in this assay, from the lowest: compounds 3, 2 and 1 (each within the scatter of the next, the first and the last beyond it).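

Among the compounds shown here, at the saturated chain carbon bound to an oxygen on an aromatic ring, the first reading in this assay is a 1.9-fold lower number from compound 2 to compound 3 (0.28 log units; within the scatter), for 3,3,3-trifluoropropyl in place of trifluoromethyl. The longer fluorinated chain is therefore accommodated at this position, with no change beyond the scatter. Still open, as far as these compounds go, is whether a plain butoxy chain without fluorine, or an amine or carboxylic acid at the chain end, would also stay within the scatter of compound 3. From the compounds shown here alone, a still longer fluorinated chain remains equally open. No evidence at hand bears on these readings.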